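Changing the Aromatic Ring on the Ring Nitrogen: Expected Toxicity

A few compounds are considered here, and "the series" means these few. Any claim that something is new, unique, unknown or untested is made for them only; others in the source may bear on it.

Compound 1 `Cc1cccc(N2CCN(CC(=O)N(c3ccccc3)c3ccccc3)CC2)c1C`: in a toxicity assay on the whole organism (strain albino) for activation, with Mus musculus as the target, with stated times of 30 min and 240 min (a higher number here means that more compound is needed for the effect, a lower number that less compound is needed), compound 1 gives only a limit, > 40 mg/kg.
Compound 2 `O=C(CN1CCN(c2cccc(C(F)(F)F)c2)CC1)N(c1ccccc1)c1ccccc1`: in this assay compound 2 gives 48 mg/kg.
Compound 3 `COc1cccc(N2CCN(CC(=O)N(c3ccccc3)c3ccccc3)CC2)c1`: in this assay compound 3 gives 55.4 mg/kg.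

Compound 3 stands highest of the two numbers; its nearest neighbour is compound 2, with a 1.2-fold higher number from compound 2 to compound 3 (0.06 log units; within the scatter). Since compound 1 gives only a limit (the limit of > 40 mg/kg in this assay, at which 1 of the 3 values shown sits), the steps a step that the limit leaves unreadable from compound 1 to compound 2 and a step that the limit leaves unreadable from compound 1 to compound 3 cannot be read.

Compound 4 `O=C(CN1CCN(c2ccc(F)cc2)CC1)N(c1ccccc1)c1ccccc1` differs from compound 3 as follows: 4-fluorophenyl in place of 3-methoxyphenyl on an amine nitrogen in a ring. Within the data shown here, the only readable step that alters the same aromatic ring, a 1.2-fold higher number from compound 2 to compound 3 (0.06 log units; within the scatter), lies within the scatter, and no measured step covers a fluorine on this ring. The expected step of a 1.1-fold lower number from compound 3 to compound 4 (0.04 log units; within the scatter) is therefore none beyond the scatter. Compound 4 is expected to give 50 mg/kg, between 28 mg/kg and 90 mg/kg.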

Compound 4, dose for half-maximal effect: > 40 mg/kg
Compound 4: only a limit was reported; the forecaster's own chance of this, stated with the estimate: 30%; the middle value lies beyond the limit too.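

Compound 4 gives only a limit, so its steps from compound 1, compound 2 and compound 3 cannot be read: the limit of > 40 mg/kg in this assay, at which 2 of the 4 values shown sit.

The compounds shown leave open how 4-fluorophenyl compares with the other aromatic rings in this assay.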